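The compounds below may be only part of what the source reports. "The series", "measured", "known", "first", "only" and "open" are said of these compounds alone.

- Compound 1 `Cn1c(=O)c(=O)n(C2CCCC2)c2nc(N/N=C/c3ccccc3)ncc21`: > 100000 nM
- Compound 2 `Cn1c(=O)c(=O)n(C2CCCC2)c2nc(N/N=C/c3cccc(Cl)c3Cl)ncc21`: 26400 nM

For the measured compounds named here, in a functional assay on HCT-116 cells (Homo sapiens) for antiproliferative activity, read by MTT assay (a lower number here means a stronger inhibitor, a higher number a weaker inhibitor), compound 2 gives 26400 nM, the only actual number available so far. Compound 1 reads > 100000 nM, which is a limit of the assay and not a number.

The next compound, compound 3 `Cn1c(=O)c(=O)n(C2CCCC2)c2nc(N/N=C/c3ccco3)ncc21`, keeps the shared core but carries furan-2-yl in place of 2,3-dichlorophenyl on a carbon with a double bond to nitrogen. Going by the values given here, only one measured step bears on this change. It is an at least 3.7-fold lower number from compound 1 to compound 2 (0.57 log units; beyond the scatter), the step that brought in the very group compound 3 gives up. As far as these compounds go, that step is beyond the scatter, although its full size is unknown, since one end of it is a limit.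

Going by an at least 3.7-fold lower number from compound 1 to compound 2 (0.57 log units; beyond the scatter), a step of similar size towards a higher number is expected in this assay, and a reading at the limit would be no surprise. Compound 3 is estimated at 60000 nM, with an expected range of 25000 nM to 100000 nM. This corresponds to an expected 2.3-fold higher number from compound 2 to compound 3 (0.36 log units; beyond the scatter).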

Compound 3, half-maximal inhibitory concentration: 78700 nM
For compound 3 the middle estimate is 1.3-fold (0.12 log units) below the measured one; the measured number falls inside the stated range.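

In this assay, furan-2-yl in place of 2,3-dichlorophenyl on a carbon with a double bond to nitrogen gives a 3.0-fold higher number from compound 2 to compound 3 (0.47 log units; beyond the scatter). For the compounds shown here, this is the first step at this position with a real number at both ends, and it shows that the lower number obtained with 2,3-dichlorophenyl does not carry over to furan-2-yl, even though the group entering brings a hydrogen-bond acceptor that the one leaving lacks. The other new step, an at least 1.2-fold lower number from compound 1 to compound 3 (0.10 log units; that floor lies within the scatter), gives only a floor, and its full size cannot be read because one of its ends is a limit and not a number: the limit of > 100000 nM in this assay, at which 1 of the 3 values shown sits.

What the compounds shown leave open is whether the lower number of the 2,3-dichlorophenyl group depends on both chlorine atoms or would also appear with a single chlorine on the phenyl ring. As far as these compounds go, it is also open how other groups at this place, such as a pyridine ring, a methoxyphenyl or a thiophene ring, would read in this assay, and so whether any of them would reach a number lower than those seen here.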